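The source may report more compounds than this note shows. Statements on the series, on what has been measured and on what is new or still open speak of the compounds shown alone.

Compound 1 `Cc1ccccc1-n1nncc1CN1C(=O)C2(C(C#N)=C(N)Oc3c2c2nc4ccccc4nc2c2ccccc32)c2ccccc21` in a functional assay on HCT-116 cells (Homo sapiens) for antiproliferative activity, read by MTT assay, with a stated time of 48 h; on this read-out lower numbers stand for stronger inhibition and higher numbers for weaker inhibition: > 50000 nM, which is a limit of the assay (the limit of > 50000 nM in this assay, at which 1 of the 3 values shown sits).
Compound 2 `N#CC1=C(N)Oc2c(c3nc4ccccc4nc3c3ccccc23)C12C(=O)N(Cc1cnnn1-c1ccc(N)cc1)c1ccccc12`: 45200 nM.
Compound 3 `CCc1ccccc1-n1nncc1CN1C(=O)C2(C(C#N)=C(N)Oc3c(N)cc4nc5ccccc5nc4c32)c2ccccc21`: 10300 nM.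

Among the two numbers shown, compound 3 stands lowest, and its gap to compound 2 lies beyond the scatter. Within the data shown here, the only measured step, an at least 1.1-fold lower number from compound 1 to compound 2 (0.04 log units; that floor lies within the scatter), swaps the group on an aromatic nitrogen; it lies within the scatter and does not speak to the change now in hand. Compound 4 `CCc1cccc(CC)c1-n1nncc1CN1C(=O)C2(C(C#N)=C(N)Oc3c(N)cc4nc5ccccc5nc4c32)c2ccccc21` differs from compound 3 by ethyl in place of hydrogen on an aromatic carbon. Among the measured compounds shown here, with no measured step of this kind to lean on, no shift beyond the scatter is expected, so the step of a 1.0-fold lower number from compound 3 to compound 4 (0.01 log units; within the scatter) is estimated to be small. Compound 4 is therefore expected to give about 10000 nM, within a range from 4000 nM to 30000 nM.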

Compound 4, half-maximal inhibitory concentration: 37600 nM
Beside the measured number, compound 4's estimate is 3.8-fold (0.58 log units) below it; the measured number lies above the stated range.
By their numbers in this assay, from the lowest: compound 3; then compounds 4 and 2 (each within the scatter of the next). At a limit, above all of these: compound 1.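

Going from 2-ethylphenyl to 2,6-diethylphenyl in this assay gives a 3.7-fold higher number from compound 3 to compound 4 (0.56 log units; beyond the scatter) and so weakens inhibition. Among these compounds, this shows that the second position ortho to the large group is not indifferent to substitution, which no earlier step could show. Nothing measured here explains this loss.

From the compounds shown here alone, whether a fluorine atom or a methoxy group at this position would also weaken inhibition remains open. So does whether an ethyl group added here would have the same effect on the core of compound 1.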